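Three Ethers, One Level, and a 4-Nitrophenyl Group Ahead

The source may report more compounds than this note shows. Statements on the series, on what has been measured and on what is new or still open speak of the compounds shown alone.

In a functional assay on A549 cells (Homo sapiens) for inhibition, read by MTT assay, with a stated time of 48 h (a higher number here means a weaker inhibitor, a lower number a stronger inhibitor), compound 1 (`Cc1ccc(OCc2cn(-c3ccc(NS(C)(=O)=O)c(Oc4ccccc4)c3)nn2)cc1`) gives 8000 nM and compound 2 (`Cc1cc(OCc2cn(-c3ccc(NS(C)(=O)=O)c(Oc4ccccc4)c3)nn2)ccc1Cl`) gives 6700 nM while compound 3 (`CS(=O)(=O)Nc1ccc(-n2cc(COc3ccc4ccccc4c3)nn2)cc1Oc1ccccc1`) gives 8300 nM as well. Compound 2 sits level with both others, and every gap among the three lies within the scatter of repeated measurements.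

Compound 4 (`CS(=O)(=O)Nc1ccc(-n2cc(COc3ccc([N+](=O)[O-])cc3)nn2)cc1Oc1ccccc1`) differs from compound 2 only in the group on the oxygen (4-nitrophenyl in place of 4-chloro-3-methylphenyl on an oxygen on a saturated carbon) with 4-nitrophenyl in place of 4-chloro-3-methylphenyl. Three measured steps at that same place bear on this change: a 1.2-fold lower number from compound 1 to compound 2 (0.08 log units; within the scatter) and a 1.0-fold higher number from compound 1 to compound 3 (0.02 log units; within the scatter) and a 1.2-fold higher number from compound 2 to compound 3 (0.09 log units; within the scatter) all stay within the scatter. From the compounds shown here alone, none of the three compounds carries a 4-nitrophenyl group, so the new group remains untested. No step beyond the scatter is expected in this assay for this change, and no firm direction can be given. The expected step is a 1.0-fold higher number from compound 2 to compound 4 (0.02 log units; within the scatter) in size. For compound 4 the estimate is 7000 nM with an expected range from 3000 nM to 16000 nM in this measurement.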

Compound 4, half-maximal inhibitory concentration: 6600 nM
Estimate against measurement, compound 4: 1.1-fold (0.03 log units) above, and the stated range covers the measured number.
By their numbers in this assay, from the lowest: compounds 4, 2, 1 and 3 (each within the scatter of the next).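

Putting 4-nitrophenyl on this oxygen brings in nitrogen, oxygen and hydrogen-bond acceptors, none of which 4-chloro-3-methylphenyl has, yet in this assay the number does not move: a 1.0-fold lower number from compound 2 to compound 4 (0.01 log units; within the scatter), a 1.3-fold lower number from compound 3 to compound 4 (0.10 log units; within the scatter) and a 1.2-fold lower number from compound 1 to compound 4 (0.08 log units; within the scatter). The level seen with the earlier groups therefore also holds for this group of a different atomic make-up, and none of the four compounds stands apart from the others. Nothing available explains why the numbers stay level at this position.

From the compounds shown here alone, it remains open whether replacing the aromatic ring on this oxygen with an amine, a carboxylic acid or a longer chain would shift the number beyond the scatter. The compounds shown also leave open what a change elsewhere on the shared core would do, since all four differ only in this one place.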